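This account rests on a few compounds, and the source may have more. Where it says the series, first, only, none or still open, it means among the compounds named here.

Series notes. Compound 1 `COc1ncc(-c2nc(C(F)(F)F)sc2N2CCN(C(=O)Cn3cnc4cccnc43)[C@H](C)C2)cn1` carries the shared core with the 2-methoxypyrimidin-5-yl group; in a functional assay on CHO-K1 cells for antagonist activity at C-X-C chemokine receptor type 3 (Homo sapiens), read by FLIPR, with a stated time of 10 min (a higher number here means a weaker inhibitor, a lower number a stronger inhibitor), compound 1 gives 3.8 nM. Compound 2 `CCOc1ncc(-c2nc(C(F)(F)F)sc2N2CCN(C(=O)Cn3cnc4cccnc43)[C@H](C)C2)cn1` differs from it by methyl in place of hydrogen on a saturated chain carbon bound to an oxygen on an aromatic ring and in this assay compound 2 gives 2 nM. The step of a 1.9-fold lower number from compound 1 to compound 2 (0.28 log units; within the scatter) is small, so no order between compound 1 and compound 2 is claimed. Compound 3 `CCc1ncc(-c2nc(C(F)(F)F)sc2N2CCN(C(=O)Cn3nc(C)nc3C)[C@H](C)C2)cn1` rests on another core; the difference between the core of compound 3 and the core of compound 1 is not broken down here. In this assay compound 3 gives 14 nM, the highest number of the three measured, beyond the scatter from both compound 1 and compound 2.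

Compound 4 `CCCc1ncc(-c2nc(C(F)(F)F)sc2N2CCN(C(=O)Cn3nc(C)nc3C)[C@H](C)C2)cn1` is not yet measured. It differs from compound 3 by methyl in place of hydrogen on a saturated chain carbon, two bonds along the chain from an aromatic carbon. This is the same kind of change as that from compound 1 to compound 2: in both a methyl enters in place of hydrogen on a saturated chain carbon, but the place is not the same, since in the earlier pair that carbon is bound to an oxygen on an aromatic ring, whereas here it is two bonds along the chain from an aromatic carbon. The change occurs twice among the compounds shown, once with a measurement. That one instance, a 1.9-fold lower number from compound 1 to compound 2 (0.28 log units; within the scatter), stayed within the scatter, so the step expected in this assay is a 1.4-fold lower number from compound 3 to compound 4 (0.15 log units; within the scatter), about as small as the earlier one; this rests on a single pair, with a different place and a different core, and is therefore uncertain. In this assay compound 4 is estimated at 10 nM, expected to fall between 4 nM and 25 nM.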

Compound 4, half-maximal inhibitory concentration: 4.4 nM
For compound 4 the middle estimate is 2.3-fold (0.36 log units) above the measured one; the range from low to high includes it.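

In this assay, replacing 2-ethylpyrimidin-5-yl with 2-propylpyrimidin-5-yl gives a 3.2-fold lower number from compound 3 to compound 4 (0.50 log units; beyond the scatter) on the core of compound 3. Set beside the methyl placed on a saturated chain carbon bound to an oxygen on an aromatic ring, on the core of compound 1, the two steps cannot be told apart, so the pairs give no sign that the core alters the size of this change: the same change on two cores in this assay, a 1.9-fold lower number (0.28 log units; within the scatter) from compound 1 to compound 2 and a 3.2-fold lower number (0.50 log units; beyond the scatter) from compound 3 to compound 4, 1.7-fold (0.22 log units) apart, within the scatter of two such steps. Going by these compounds alone, this does not establish that the change carries from one core to another, since there are only two pairs, they differ in the place of the methyl as well as in the core, and the earlier step alone stays within the scatter.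

On these data alone, the separate contributions of core and place remain open, and would need the same chain change at the same place on both cores, for example a 2-propylpyrimidin-5-yl group on the core of compound 1. Also open, as far as these compounds go, is how far the chain can be extended or altered at this place, whether with a longer chain such as butyl, a branched chain such as isopropyl, or a terminal amine or carboxylic acid.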